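Notes on a chloro addition to compound 1

A few compounds are considered here, and "the series" means these few. Any claim that something is new, unique, unknown or untested is made for them only; others in the source may bear on it.

Compound 1 `CC(=O)OC/C(=C\c1ccc(Cl)cc1)C(=O)c1ccccc1` gives the lowest number of the three measured in a functional assay on WiDr cells (Homo sapiens) for inhibition, read by sulforhodamine B assay, with a stated time of 48 h (a higher number here means a weaker inhibitor of growth, a lower number a stronger inhibitor of growth), at 4800 nM. Compound 2 `CC(=O)OC/C(=C\c1ccccc1Br)C(=O)c1ccccc1` gives 21000 nM in this assay, and compound 3 `CC(=O)OC/C(=C\c1ccccc1F)C(=O)c1ccccc1` gives 19000 nM. The steps of a 4.4-fold higher number from compound 1 to compound 2 (0.64 log units; beyond the scatter) and a 4.0-fold higher number from compound 1 to compound 3 (0.60 log units; beyond the scatter) both set compound 1 apart from the other two beyond the scatter, while the step of a 1.1-fold lower number from compound 2 to compound 3 (0.04 log units; within the scatter) does not separate compound 2 from compound 3.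

Compound 4 `CC(=O)OC/C(=C\c1ccc(Cl)cc1)C(=O)c1ccc(Cl)cc1` differs from compound 1 by chloro in place of hydrogen on an aromatic carbon. Going by the values given here, this chloro enters a different ring from the one on the double-bonded chain carbon where compounds 2 and 3 differ from compound 1, so none of the measured steps bears directly on it. The only steps in hand, a 4.4-fold higher number from compound 1 to compound 2 (0.64 log units; beyond the scatter) and a 4.0-fold higher number from compound 1 to compound 3 (0.60 log units; beyond the scatter), show that a halogen change on that other ring moves the number modestly; what a chloro on the ring of the present change does is not shown by any measured pair. Among the compounds with values here, with no step touching this ring, no change beyond the scatter is expected in this assay, and the step is estimated as a 1.1-fold lower number from compound 1 to compound 4 (0.03 log units; within the scatter). Compound 4 is therefore expected to give 4500 nM in this assay, within 1500 nM to 14000 nM.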

Compound 4, concentration for 50% growth inhibition: 18000 nM
Compound 4: middle estimate off by 4.0-fold (0.60 log units), on the low side, and the stated range ends below it.
By their numbers in this assay, from the lowest: compound 1; then compounds 4, 3 and 2 (each within the scatter of the next).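

Phenyl to 4-chlorophenyl on the ring left unsubstituted in compound 1 gives a 3.8-fold higher number from compound 1 to compound 4 (0.57 log units; beyond the scatter) in this assay, so a single chloro at this place, para to a large group, is enough to move the number beyond the scatter towards a weaker inhibitor of growth. The earlier steps shown here concerned only the other aryl ring, whereas this one shows that the number also responds to a change on the ring left unsubstituted in compound 1, and compound 1 remains the lowest of the four, with compounds 2, 3 and 4 each printed beyond the scatter above it. Nothing measured here accounts for the rise.

On these data alone, it remains open whether the higher number belongs to chloro in particular or would follow any group entering at this place, such as fluoro, methoxy, an amine or a carboxylic acid, and whether the same chloro would have a different effect elsewhere on this ring. Also open, as far as these compounds go, is how the series would respond if the acetate ester of the shared core gave way to a longer chain or an amide.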